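The compounds below may be only part of what the source reports. "The series", "measured", "known", "first", "only" and "open" are said of these compounds alone.

Measured in a toxicity assay on MT2 cells (Homo sapiens) for cytotoxicity; a lower number here means that less compound is tolerated, a higher number that more compound is tolerated:
- compound 1 `Cc1nc(C)c([C@H](OC(C)(C)C)C(=O)O)c(N2CCC(C)(C)CC2)c1-c1cnn(CCCc2ccc(F)cc2)c1`: >= 22000 nM (limit)
- compound 2 `Cc1nc(C)c([C@H](OC(C)(C)C)C(=O)O)c(N2CCC(C)(C)CC2)c1-c1cnc(OCCc2ccc(F)cc2)nc1`: >= 22000 nM (limit)
- compound 3 `Cc1nc(C)c([C@H](OC(C)(C)C)C(=O)O)c(N2CCC(C)(C)CC2)c1-c1ccc2c(c1)CCN(Cc1cccc(F)c1C)C2`: >= 24000 nM (limit)

Compound 3 stands at >= 24000 nM, which is a limit and not a number. For the measured compounds named here, the other two compounds also gave only limits, so no measured compound yet has a numerical value and no order can be drawn among them.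

Compound 4 `Cc1nc(C)c([C@H](OC(C)(C)C)C(=O)O)c(N2CCC(C)(C)CC2)c1-c1ccc2c(c1)CCN(c1nccc(-c3cnccn3)n1)C2` has not yet been measured in this assay. It differs from compound 3 on an amine nitrogen in a ring: a group of 12 heavy atoms (8 carbon, 4 nitrogen; 2 six-membered aromatic rings with 2 hetero atoms each) in place of a group of 9 heavy atoms (8 carbon, 1 fluorine; one six-membered aromatic ring of carbon only), on an amine nitrogen in a ring.

Going by the values given here, no step between measured compounds is available to size this change. Compound 1, compound 2 and compound 3 carry different groups on the shared core, and all three stop at a limit. On that basis, no change beyond the scatter is expected, with any shift more likely downward. The expected change is an at least 1.1-fold lower number from compound 3 to compound 4 (0.05 log units; that floor lies within the scatter). A further limit is the likeliest report. For compound 4 the estimated value is 21000 nM, with an expected range of 8000 nM to 40000 nM.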

Compound 4, half-maximal cytotoxic concentration: >= 17000 nM
Compound 4 gave a limit, no number (the forecaster's own chance of this, stated with the estimate: 70%); the middle value does not contradict the limit.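

Compound 3 and compound 4 both stop at a limit in this assay, so no step can be read between them. The compounds shown leave open whether the group on the amine nitrogen in a ring shifts the half-maximal cytotoxic concentration at all.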